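Sulfonamide Variations Against Mitochondrial Malate Dehydrogenase

The source may hold more compounds than are shown below. What is called first, only, known or untested is meant among the compounds shown, and "the series" means these compounds.

Three sulfonamides built on one shared core have been tested in an assay on isolated protein for inhibition of malate dehydrogenase, mitochondrial (Sus scrofa), with stated times of 45 min and 30 min; a higher number here means a weaker inhibitor, a lower number a stronger inhibitor. Compound 1, `O=S(=O)(Nc1ccc(-c2nc3ccccc3o2)cc1)c1ccccc1Cl`, gives in this assay only a limit of > 63000 nM and no number. Compound 2, `O=S(=O)(Nc1ccc(-c2nc3ccccc3o2)cc1)c1ccccc1F`, likewise gives in this assay only a limit of > 63000 nM. Compound 3, `O=S(=O)(Nc1ccc(-c2nc3ccccc3o2)cc1)c1cccs1`, gives in this assay a limit of > 63000 nM as well. Every value shown is a limit. The steps a step that the two limits leave unreadable from compound 1 to compound 2, a step that the two limits leave unreadable from compound 1 to compound 3 and a step that the two limits leave unreadable from compound 2 to compound 3 cannot be sized. Compound 3 therefore stands where all three sit, at the limit of > 63000 nM in this assay, at which 3 of the 3 values shown sit.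

Compound 4, `O=S(=O)(Nc1ccc(-c2nc3ccccc3o2)cc1)c1ccc(F)cc1`, differs from compound 3 by 4-fluorophenyl in place of thiophen-2-yl on a sulfonyl sulfur. The steps a step that the two limits leave unreadable from compound 1 to compound 3 and a step that the two limits leave unreadable from compound 2 to compound 3 bear on this change, since they also exchange the group on the sulfonyl sulfur, yet neither is readable in size. Nothing measured suggests that compound 4 will leave the region of the limit, so the step that the limit leaves unreadable from compound 3 to compound 4 is expected to be none beyond the scatter. Compound 4 is accordingly expected to give about 90000 nM in this assay, within a range from 20000 nM to 400000 nM, and most likely to be reported again only as a limit.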

Compound 4, half-maximal inhibitory concentration: > 63000 nM
Compound 4 was reported as a limit (the forecaster's own chance of this, stated with the estimate: 85%); the middle value lies beyond the limit too.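

Compound 4 adds no readable step in this assay: its comparisons with compound 1, compound 2 and compound 3 each join two limits, so none can be sized. All four compounds sit together: the limit of > 63000 nM in this assay, at which 4 of the 4 values shown sit. The compounds shown leave open whether any group on the sulfonyl sulfur gives a measurable inhibition, and how these four truly compare.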